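Series notes: ethyl capping the aromatic oxygen of compound 2

This account rests on a few compounds, and the source may have more. Where it says the series, first, only, none or still open, it means among the compounds named here.

Measured compounds in an assay on isolated protein for inhibition of ribosomal protein S6 kinase alpha-2 (Homo sapiens), read by fluorescence, with a stated time of 20 min; on this read-out higher numbers stand for weaker inhibition and lower numbers for stronger inhibition:
Compound 1, `CCc1ccc(NCN2C(=O)c3ccccc3C2=O)cc1`, gives 4310 nM.
Compound 2, `O=C1c2ccccc2C(=O)N1CNc1ccc(O)cc1`, gives 520 nM.

Within the data shown here, compound 2 carries the lower of the two numbers in this assay; its only neighbour is compound 1, and the single measured step, an 8.3-fold lower number from compound 1 to compound 2 (0.92 log units; beyond the scatter), lies beyond the scatter, with hydroxy in place of ethyl on an aromatic carbon.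

Compound 3, `CCOc1ccc(NCN2C(=O)c3ccccc3C2=O)cc1`, has not yet been measured in this assay. It differs from compound 2 by ethyl in place of hydrogen on an oxygen on an aromatic ring; cut one bond further out the change reads hydroxy to ethoxy.

The step from compound 1 to compound 2 is the only one that bears on this change, and only indirectly: it shows that the hydroxy group on that aromatic carbon goes with a lower number than ethyl does, while compound 3 keeps the oxygen but caps it with ethyl. Among the measured compounds shown here, no measured pair alters the substituent on this oxygen, so the direction rests on compound 3 sitting structurally between compound 1 and compound 2. A modest rise in the number from compound 2 to compound 3 is therefore expected, a 2.9-fold higher number from compound 2 to compound 3 (0.46 log units; beyond the scatter), but a result within the scatter of compound 2 would not surprise. Compound 3 is estimated at 1500 nM, in the range 500 nM to 5000 nM.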

Compound 3, half-maximal inhibitory concentration: 590 nM
Beside the measured number, compound 3's estimate is 2.5-fold (0.41 log units) above it; the range from low to high includes it.
By their numbers in this assay, from the lowest: compounds 2 and 3 (each within the scatter of the next); then compound 1.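

In this assay, the hydrogen on the oxygen on the aromatic ring can give way to ethyl without a change that stands out from the scatter (a 1.1-fold higher number from compound 2 to compound 3 (0.05 log units; within the scatter)), so a free hydroxy is not required for the number seen with compound 2. The advantage over the ethyl-bearing compound also survives the capping (a 7.3-fold lower number from compound 1 to compound 3 (0.86 log units; beyond the scatter)): among these three compounds, the lower numbers go with an oxygen on the aromatic carbon, whether it carries hydrogen or ethyl, and compound 1, the only one without that oxygen, has the highest number. Nothing at hand explains why the oxygen goes with lower numbers or why ethyl on it leaves the number within the scatter.

Going by these compounds, how far this tolerance extends remains open, since only hydrogen and ethyl appear on the oxygen, and a longer chain such as butyl, a benzyl group or a carboxylic acid there would probe its limits. On these data alone, it is also open whether oxygen itself is what counts, a question that an amine or a methylthio group on the same aromatic carbon would address.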